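Swapping trifluoromethyl for hydroxy on a weakly active scaffold

A few compounds are considered here, and "the series" means these few. Any claim that something is new, unique, unknown or untested is made for them only; others in the source may bear on it.

Compound 1 `O=C(/C=C\Nc1ccc(O)cc1)c1cn(-c2ccccc2)nc1-c1ccccc1`: 44600 nM
Compound 2 `COc1ccc(-c2nn(-c3ccccc3)cc2C(=O)/C=C\Nc2ccc(F)cc2)cc1`: 8910 nM
Compound 3 `COc1ccc(-c2nn(-c3ccccc3)cc2C(=O)/C=C\Nc2ccc(C(F)(F)F)cc2)cc1`: > 50000 nM

The three measured compounds were tested in an ADME assay on HaCaT cells (Homo sapiens) for antiproliferative activity, read by MTT assay, with a stated time of 48 h; on this read-out lower numbers stand for stronger inhibition and higher numbers for weaker inhibition. Compound 1 gives 44600 nM, compound 2 gives 8910 nM, and for compound 3 the result is only a limit of the assay, > 50000 nM. Among the compounds with values here, the one single-point step seen so far is an at least 5.6-fold higher number from compound 2 to compound 3 (0.74 log units; beyond the scatter), so compound 3 stands at the weak end, as the evidence the limit of > 50000 nM in this assay, at which 1 of the 3 values shown sits, states.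

Compound 4 `COc1ccc(-c2nn(-c3ccccc3)cc2C(=O)/C=C\Nc2ccc(O)cc2)cc1` differs from compound 3 by hydroxy in place of trifluoromethyl on an aromatic carbon. Within the data shown here, no measured step covers this exact exchange; compound 1 carries the same hydroxy group on a related core and sits near the limit. The step from compound 3 to compound 4 is therefore expected to be small, an at least 1.2-fold lower number from compound 3 to compound 4 (0.09 log units; that floor lies within the scatter). Compound 4 is estimated at 40000 nM, within 12000 nM to 150000 nM.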

Compound 4, half-maximal inhibitory concentration: 34600 nM
Estimate against measurement, compound 4: 1.2-fold (0.06 log units) above; the measured number falls inside the stated range.
By their numbers in this assay, from the lowest: compound 2; then compounds 4 and 1 (each within the scatter of the next). At a limit, above all of these: compound 3.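

Hydroxy in place of fluoro gives a 3.9-fold higher number from compound 2 to compound 4 (0.59 log units; beyond the scatter), so at this position on the shared core, fluoro keeps a modest edge over hydroxy. Methoxy in place of hydrogen gives a 1.3-fold lower number from compound 1 to compound 4 (0.11 log units; within the scatter), so with hydroxy present, this exchange makes no readable difference. Hydroxy in place of trifluoromethyl gives an at least 1.4-fold lower number from compound 3 to compound 4 (0.15 log units; that floor lies within the scatter), and the true size of this step stays unknown because one end of it is only a limit: the limit of > 50000 nM in this assay, at which 1 of the 4 values shown sits.

From the compounds shown here alone, whether an amine, a carboxylic acid or a chloro group at this position would match fluoro remains open. So does whether methoxy matters when fluoro occupies this position.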